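This account rests on a few compounds, and the source may have more. Where it says the series, first, only, none or still open, it means among the compounds named here.

Measured so far:
- compound 1, `CCc1ccc2oc(CSc3nnc(CNc4ccccc4)n3CC)nc2c1`: > 1000 nM
- compound 2, `CCn1c(CNc2ccccc2)nnc1SCC(=O)Nc1ccccc1`: > 1000 nM

In an assay on isolated protein for inhibition of long-chain fatty acid transport protein 1 (Homo sapiens) (on this read-out higher numbers stand for weaker inhibition and lower numbers for stronger inhibition), compound 1 gives only a limit, > 1000 nM. Compound 2 likewise returns a limit, > 1000 nM. Compound 1 thus stands at the limit of > 1000 nM in this assay, at which 2 of the 2 values shown sit, so no ordering among the series can be read from the numbers.

Compound 3, `CC/C(=N/O)c1ccc2oc(CSc3nnc(CNc4ccccc4)n3CC)nc2c1`, differs from compound 1 by a group of 5 heavy atoms (3 carbon, 1 nitrogen, 1 oxygen; no ring) in place of a group of 2 heavy atoms (2 carbon; no ring), on an aromatic carbon. Among the measured compounds shown here, no step of this kind has been measured here. The expected step is a step that the limit leaves unreadable from compound 1 to compound 3, not beyond the scatter. Compound 3 is expected near 2000 nM, in the range 500 nM to 10000 nM, most likely again a limit in this assay.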

Compound 3, half-maximal inhibitory concentration: 260 nM
Beside the measured number, compound 3's estimate is 7.7-fold (0.89 log units) above it; the whole stated range lies above it.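

Replacing ethyl with the group of 5 heavy atoms on this aromatic carbon gives an at least 3.8-fold lower number from compound 1 to compound 3 (0.58 log units; beyond the scatter) in this assay. Among the compounds shown here, this is the first sign that the position affects the read-out, as the earlier compounds gave no ordering. The true size of the step remains unknown, since its starting point is a limit: the limit of > 1000 nM in this assay, at which 2 of the 3 values shown sit.

Which feature of the entering group accounts for the step remains open. A simple ketone, an amine or a longer chain at this position would help separate the contribution of its atoms from that of its length.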